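Swapping the amide aryl group on a benzimidazole chalcone

The source may hold more compounds than are shown below. What is called first, only, known or untested is meant among the compounds shown, and "the series" means these compounds.

Going by the values given here, compound 2 `O=C(Nc1cccc(/C=C/C(=O)c2nc3ccccc3[nH]2)c1)c1cccc(C(F)(F)F)c1` gives 21500 nM in a functional assay on MCF7 cells (Homo sapiens) for antiproliferative activity, read by MTT assay, with a stated time of 48 h (a higher number here means a weaker inhibitor, a lower number a stronger inhibitor), the higher of the two numbers known here; compound 1 `O=C(/C=C/c1cccc(NC(=O)c2ccccc2Br)c1)c1nc2ccccc2[nH]1` gives 4520 nM in this assay. Among the compounds with values here, the single known step, a 4.8-fold higher number from compound 1 to compound 2 (0.68 log units; beyond the scatter), concerns the same carbonyl carbon. Compound 3 `Cc1cc(C)cc(C(=O)Nc2cccc(/C=C/C(=O)c3nc4ccccc4[nH]3)c2)c1` differs from compound 2 by 3,5-dimethylphenyl in place of 3-(trifluoromethyl)phenyl on a carbonyl carbon. Within the data shown here, no step with a 3,5-dimethylphenyl group has been measured, so the direction is uncertain, and a change near or slightly beyond the scatter is expected: a 1.8-fold lower number from compound 2 to compound 3 (0.25 log units; within the scatter). Compound 3 is estimated at 12000 nM, in a range from 4000 nM to 40000 nM.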

Compound 3, half-maximal inhibitory concentration: 24600 nM
Estimate against measurement, compound 3: 2.1-fold (0.31 log units) below, and the stated range covers the measured number.
By their numbers in this assay, from the lowest: compound 1; then compounds 2 and 3 (each within the scatter of the next).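

In this assay the position tolerates this exchange without a readable change, with a 1.1-fold higher number from compound 2 to compound 3 (0.06 log units; within the scatter), so compounds 2 and 3 cannot be ordered. Against 2-bromophenyl the same exchange gives a 5.4-fold higher number from compound 1 to compound 3 (0.74 log units; beyond the scatter), which leaves compound 1 the strongest of the three, apart from two differently substituted phenyl groups. Nothing measured here accounts for these differences. On these data alone, it remains open whether 2-chlorophenyl or 3-bromophenyl on this carbonyl carbon would fall with compound 1 or with compounds 2 and 3, and what an amine or a carboxylic acid on the ring would do.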